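Phenyl for methyl on an aromatic carbon of compound 1

The compounds below may be only part of what the source reports. "The series", "measured", "known", "first", "only" and "open" are said of these compounds alone.

Compound 1 `CC(=O)c1ccc2c(c1O)[C@@H]1c3c(ccc4c(=O)c(C)c(C)oc34)OC[C@@H]1C(C)(C)O2` gives > 100000 nM in a functional assay on A549 cells (Homo sapiens) for cytotoxicity, read by MTT assay (on this read-out higher numbers stand for weaker inhibition and lower numbers for stronger inhibition), a limit of the assay and not a number.
Compound 2 `Cc1oc2c3c(ccc2c(=O)c1C)OC[C@H]1[C@@H]3c2c(ccc(C(=O)Cc3ccccc3)c2O)OC1(C)C` gives > 100000 nM in this assay, again a limit.
Compound 3 `Cc1oc2c3c(ccc2c(=O)c1C)OC[C@H]1[C@@H]3c2c(ccc(C(=O)c3ccccc3)c2O)OC1(C)C` gives > 100000 nM in this assay, also a limit.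

All three values rest at the limit (the limit of > 100000 nM in this assay, at which 3 of the 3 values shown sit), so compound 1 stands only at a limit, with no number of its own. The changes among the measured compounds, a step that the two limits leave unreadable from compound 1 to compound 2, a step that the two limits leave unreadable from compound 1 to compound 3 and a step that the two limits leave unreadable from compound 2 to compound 3, stay unreadable for the same reason.

Compound 4 `CC(=O)c1ccc2c(c1O)[C@@H]1c3c(ccc4c(=O)c(-c5ccccc5)c(C)oc34)OC[C@@H]1C(C)(C)O2` differs from compound 1 by phenyl in place of methyl on an aromatic carbon. Among the measured compounds shown here, no measured step touches this position, and none of the measured steps has a readable size, so no direction beyond the scatter can be drawn for this assay. Compound 4 is therefore expected to stay at the limit, estimated at 100000 nM, between 40000 nM and 300000 nM. The expected step is a number no higher from compound 1 to compound 4 (the limit leaves the size open).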

Compound 4, half-maximal inhibitory concentration: 2530 nM
Compound 4: the middle estimate sits 40-fold (1.60 log units) above what was measured; measured number below the stated range.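

Phenyl in place of methyl on this aromatic carbon, two atoms from the ring oxygen, gives in this assay the only readable step so far: an at least 39-fold lower number from compound 1 to compound 4 (1.59 log units; beyond the scatter). The position therefore responds where the changes on the carbonyl carbon could not be read, as the steps among compound 1, compound 2 and compound 3 all stay unreadable at the limit: the limit of > 100000 nM in this assay, at which 3 of the 4 values shown sit.

Only methyl and phenyl are shown on this carbon, so whether an amine, a carboxylic acid or a longer chain there would also leave the limit stays open. As far as these compounds go, whether the step survives with benzyl or phenyl on the carbonyl carbon is also open.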